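Aryl amide swap on a naphthalene hexafluoro-carbinol core

This account rests on a few compounds, and the source may have more. Where it says the series, first, only, none or still open, it means among the compounds named here.

Compound 1 `CC(C)CCC(=O)Nc1c(C(O)(C(F)(F)F)C(F)(F)F)ccc2ccccc12` gives 49 nM in an assay on LtK cells with ATP-sensitive inward rectifier potassium channel 11 (Homo sapiens) as the target; a higher number here means that more compound is needed for the effect, a lower number that less compound is needed. Compound 2 `O=C(NCCCCCCCl)Nc1c(C(O)(C(F)(F)F)C(F)(F)F)ccc2ccccc12` gives 4840 nM. Compound 3 `O=C(Nc1c(C(O)(C(F)(F)F)C(F)(F)F)ccc2ccccc12)c1cccc(Cl)c1` gives 98 nM.

Compound 1 has the lowest number of the three, with compound 3 nearest and compound 2 furthest, by a 2.0-fold higher number from compound 1 to compound 3 (0.30 log units; within the scatter) and a 99-fold higher number from compound 1 to compound 2 (1.99 log units; beyond the scatter). The unmeasured compound 4 `O=C(Nc1c(C(O)(C(F)(F)F)C(F)(F)F)ccc2ccccc12)c1ccc(Br)cc1` differs from compound 1 by 4-bromophenyl in place of isopentyl on a carbonyl carbon. For the measured compounds named here, the step that bears on this is the one to compound 3, where a 3-chlorophenyl group also took the place of isopentyl on a carbonyl carbon and changed the number only by a 2.0-fold higher number from compound 1 to compound 3 (0.30 log units; within the scatter). The large loss to compound 2 came with a (6-chlorohexyl)amino group, a different kind of change. Compound 4 is therefore expected to show at most a small step, a 2.0-fold higher number from compound 1 to compound 4 (0.31 log units; beyond the scatter), giving an estimated 100 nM with a range of 35 nM to 300 nM.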

Compound 4, half-maximal effective concentration: 47 nM
The estimate for compound 4 lay 2.1-fold (0.33 log units) above the measured number; measured number inside the range.
By their numbers in this assay, from the lowest: compounds 4, 1 and 3 (each within the scatter of the next, the first and the last beyond it); then compound 2.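

Putting 4-bromophenyl in place of isopentyl on the carbonyl carbon leaves the number level (a 1.0-fold lower number from compound 1 to compound 4 (0.02 log units; within the scatter)), so this position accepts a halogen-bearing aromatic ring as well as a branched chain. Among the two aromatic rings, the change from 3-chlorophenyl to 4-bromophenyl gives a modest step (a 2.1-fold lower number from compound 3 to compound 4 (0.32 log units; beyond the scatter)), while the gap from the (6-chlorohexyl)amino group stays large (a 100-fold lower number from compound 2 to compound 4 (2.01 log units; beyond the scatter)). No measurement here explains these steps.

As far as these compounds go, whether a methoxy group on the ring or a pyridine ring would keep the number this low remains open. So does whether the loss in compound 2 follows its added nitrogen or its chain, which a plain hexyl group on the carbonyl carbon could help separate.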